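Dimethylamino in place of 1H-imidazol-1-yl

The compounds below may be only part of what the source reports. "The series", "measured", "known", "first", "only" and "open" are said of these compounds alone.

Compound 1 (`CC(=O)N(C)C(C)C#CCn1cncc1C`) gives in a functional assay on the whole organism for agonist activity, with Mus musculus as the target (on this read-out higher numbers stand for an effect only at larger amounts of compound and lower numbers for an effect already at smaller amounts), only a limit of > 100 mg/kg and no number. Compound 2 (`CC1CCC(=O)N1CC#CCn1ccnc1`) likewise reaches only a limit of > 100 mg/kg and no number. Compound 3 (`Cc1cncn1CC#CCN1C(=O)CCC1C`) also shows just a limit of > 100 mg/kg as its sole result. The series therefore rests entirely on the limit of > 100 mg/kg in this assay, at which 3 of the 3 values shown sit, and compound 2 has no readable place within it. Within the data shown here, the one measured step, a step that the two limits leave unreadable from compound 2 to compound 3 for methyl in place of hydrogen on an aromatic carbon, supplies no size to carry forward.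

Compound 4 (`CC1CCC(=O)N1CC#CCN(C)C`) differs from compound 2 by dimethylamino in place of 1H-imidazol-1-yl on a saturated chain carbon bound to a triple-bonded carbon and so carries dimethylamino in place of 1H-imidazol-1-yl on a saturated chain carbon bound to a triple-bonded carbon. Among the measured compounds shown here, no measured step touches this change, and its size cannot be derived from the data. Because compound 2 sits at the limit > 100 mg/kg in this assay any readable result can only point towards smaller doses, though a further limit remains possible. The expected move is an at least 5.0-fold lower number from compound 2 to compound 4 (0.69 log units; beyond the scatter) as a rough estimate with wide uncertainty. For compound 4 the estimated value is 20 mg/kg in a range expected to run from 2 mg/kg to 150 mg/kg in this deliberately broad estimate.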

Compound 4, dose for half-maximal effect: 3 mg/kg
Beside the measured number, compound 4's estimate is 6.7-fold (0.82 log units) above it; the range from low to high includes it.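

In this assay the change on a saturated chain carbon bound to a triple-bonded carbon, dimethylamino in place of 1H-imidazol-1-yl, gives an at least 33-fold lower number from compound 2 to compound 4 (1.52 log units; beyond the scatter) and so brings the first readable number into the series. Among these compounds, this shows that the result responds to the group at this place, something the earlier compounds could not show while all of them stayed at a single limit. The size printed is only a lower bound because the step starts from a limit: the limit of > 100 mg/kg in this assay, at which 3 of the 4 values shown sit.

As far as these compounds go, the step for methyl in place of hydrogen on an aromatic carbon cannot be read, so it remains open whether that methyl matters at all, and whether dimethylamino would lift the amide side of compound 1 to a readable value as it does for the shared core of compound 4. From the compounds shown here alone, it also remains open how far the effect depends on dimethylamino itself, since another amine at the same place, such as diethylamino or pyrrolidin-1-yl, could match it, exceed it or fall back to the limit.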